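Methyl in Place of Chloro on the Thiophene of Compound 2

The source may hold more compounds than are shown below. What is called first, only, known or untested is meant among the compounds shown, and "the series" means these compounds.

Compound 1 `CC(C)Nc1sc(C(=O)c2ccco2)c(N)c1C#N`: 1350 nM
Compound 2 `CC(C)Nc1sc(C(=O)c2ccc(Cl)s2)c(N)c1C#N`: 192 nM

In an assay for inhibition of Maternal embryonic leucine zipper kinase (Homo sapiens), read by ADP-Glo, with a stated time of 0.5 h (a higher number here means a weaker inhibitor, a lower number a stronger inhibitor), compound 2 holds the lowest of the two numbers shown. Within the data shown here, its only neighbour is compound 1, and the sole measured step, a 7.0-fold lower number from compound 1 to compound 2 (0.85 log units; beyond the scatter), came from the carbonyl-borne ring exchange. Compound 3 `Cc1ccc(C(=O)c2sc(NC(C)C)c(C#N)c2N)s1` differs from compound 2 by methyl in place of chloro on an aromatic carbon. Among the measured compounds shown here, only one measured step exists, and it bears loosely at best: a 7.0-fold lower number from compound 1 to compound 2 (0.85 log units; beyond the scatter) swapped the whole ring together with its substituent, so it does not isolate what a single change of substituent on the thiophene does. For the measured compounds named here, no step exchanges chloro for methyl. With such thin backing, a step within the scatter, or at most a small rise in the number, is expected in this assay. Compound 3 is therefore estimated at 260 nM, with a range from 90 nM to 750 nM, which amounts to an expected 1.4-fold higher number from compound 2 to compound 3 (0.13 log units; within the scatter).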

Compound 3, half-maximal inhibitory concentration: 494 nM
Beside the measured number, compound 3's estimate is 1.9-fold (0.28 log units) below it; the measured number falls inside the stated range.
By their numbers in this assay, from the lowest: compound 2; then compound 3; then compound 1.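

In this assay, among these compounds, methyl in place of chloro gives a 2.6-fold higher number from compound 2 to compound 3 (0.41 log units; beyond the scatter) with the thiophene left unchanged, which isolates the substituent at this place for the first time and shows that the two groups are not interchangeable here. The methyl compound still keeps part of the advantage over the furan, with a 2.7-fold lower number from compound 1 to compound 3 (0.44 log units; beyond the scatter) beside the larger 7.0-fold lower number from compound 1 to compound 2 (0.85 log units; beyond the scatter) on the chloro side, so that advantage does not depend on chloro alone. Nothing measured here accounts for the difference between chloro and methyl.

The compounds shown leave open how a thiophene with only hydrogen at this place would compare, so the shares of ring and substituent remain unsettled. Also open, on these data alone, is how bromo, methoxy or a longer chain such as ethyl would fare here.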